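A few compounds are considered here, and "the series" means these few. Any claim that something is new, unique, unknown or untested is made for them only; others in the source may bear on it.

Three compounds of the series share one core and differ only in the group carried on an aromatic nitrogen. Compound 1 `Cc1ccccc1-c1nn(-c2cccc(Cl)c2)cc1CNCCN1CCN(C)CC1` gives 16000 nM in an ADME assay on Huh-7 cells (Homo sapiens) for cytotoxicity; a lower number here means that less compound is tolerated, a higher number that more compound is tolerated. Compound 2 `Cc1ccccc1-c1nn(-c2ccc(Br)cc2)cc1CNCCN1CCN(C)CC1` gives 9600 nM in this assay, and compound 3 `Cc1ccccc1-c1nn(-c2ccc(OC(F)(F)F)cc2)cc1CNCCN1CCN(C)CC1` gives 17000 nM in this assay. Compound 3 holds the highest of the three numbers, its nearest neighbour being compound 1 and the furthest compound 2, yet both gaps lie within the scatter, so no order among the three can be read. The steps say the same: a 1.7-fold lower number from compound 1 to compound 2 (0.22 log units; within the scatter), a 1.1-fold higher number from compound 1 to compound 3 (0.03 log units; within the scatter) and a 1.8-fold higher number from compound 2 to compound 3 (0.25 log units; within the scatter), each within the scatter.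

Compound 4 `Cc1ccccc1-c1nn(Cc2ccc(F)cc2)cc1CNCCN1CCN(C)CC1` has not yet been measured. It differs from compound 3 as follows: 4-fluorobenzyl in place of 4-(trifluoromethoxy)phenyl on an aromatic nitrogen. Among the measured compounds shown here, none of the measured steps covers this change; each of them exchanges the 3-chlorophenyl, 4-bromophenyl or 4-(trifluoromethoxy)phenyl group for another of these on the same nitrogen, and each stayed within the scatter. For the measured compounds named here, with no step bearing directly on the change, the expectation rests on the flat run of the three numbers in this assay. For compound 4 a step of a 1.1-fold lower number from compound 3 to compound 4 (0.05 log units; within the scatter) is therefore expected, that is, none beyond the scatter. Compound 4 is estimated at 15000 nM, with a range from 6000 nM to 40000 nM.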

Compound 4, half-maximal cytotoxic concentration: > 20000 nM
Compound 4: only a limit was reported (the forecaster's own chance of this, stated with the estimate: 10%); middle value at least 1.3-fold (0.12 log units) from the limit.
By their numbers in this assay, from the lowest: compounds 2, 1 and 3 (each within the scatter of the next). At a limit, above all of these: compound 4.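

In this assay compound 4 gives > 20000 nM, which is a limit of the assay and not a number: the limit of > 20000 nM in this assay, at which 1 of the 4 values shown sits. Even so, the change can be read against one neighbour as an at least 2.0-fold higher number from compound 2 to compound 4 (0.31 log units; beyond the scatter), whereas the readings an at least 1.1-fold higher number from compound 3 to compound 4 (0.07 log units; that floor lies within the scatter) and an at least 1.2-fold higher number from compound 1 to compound 4 (0.09 log units; that floor lies within the scatter) leave open whether compound 4 differs from compound 3 or compound 1 at all. Among the compounds shown here, this aromatic nitrogen, until now seen only with substituted phenyl groups, thus also carries a 4-fluorobenzyl group with no lower number in this assay, and the one step beyond the scatter is the step from the 4-bromophenyl group of compound 2.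

The compounds shown do not separate the methylene link of the benzyl group from the change of ring substituent, since an unsubstituted benzyl, a 4-bromobenzyl or a 4-(trifluoromethoxy)benzyl group does not appear among them. Also open, as far as these compounds go, is how this nitrogen behaves in this assay with a longer chain such as 2-phenylethyl, or with a ring bearing an amine or a carboxylic acid.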